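The source may report more compounds than this note shows. Statements on the series, on what has been measured and on what is new or still open speak of the compounds shown alone.

Measured compounds:
compound 1 `CC(C)Cn1nc(C(=O)N[C@H]2COc3ccccc3N(C)C2=S)nc1Cc1ccccc1` — 1230 nM
compound 2 `COCCn1nc(C(=O)N[C@H]2COc3ccccc3N(C)C2=S)nc1Cc1ccccc1` — 566 nM

Both were run in a functional assay on HT-29 cells (Homo sapiens) for inhibition, read by luminescence and CellTiter-Glo, with a stated time of 24 h; a higher number here means that more compound is needed for the effect, a lower number that less compound is needed. Compound 1 holds the highest number of the two, with compound 2 nearest; the gap is a 2.2-fold lower number from compound 1 to compound 2 (0.34 log units; beyond the scatter), a modest step that nevertheless clears the scatter.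

Compound 3 `CN1C(=S)[C@@H](NC(=O)c2nc(Cc3ccccc3)n(CCCCC#N)n2)COc2ccccc21` is not yet measured. It differs from compound 1 as 3-cyanopropyl in place of isopropyl on a saturated chain carbon bound to an aromatic nitrogen. For the measured compounds named here, the only measured step that bears on this is a 2.2-fold lower number from compound 1 to compound 2 (0.34 log units; beyond the scatter), where methoxymethyl replaced isopropyl at the same place. Both changes exchange isopropyl at that carbon for an oxygen- or nitrogen-bearing chain, so a modest step in the same direction is expected in this assay, while nothing measured tells how a longer chain at this carbon behaves. Compound 3 is therefore expected near 700 nM, within a range from 300 nM to 1600 nM. The estimated step is a 1.8-fold lower number from compound 1 to compound 3 (0.24 log units; within the scatter).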

Compound 3, half-maximal effective concentration: 2680 nM
The estimate for compound 3 lay 3.8-fold (0.58 log units) below the measured number; the whole stated range lies below it.
By their numbers in this assay, from the lowest: compound 2; then compound 1; then compound 3.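

In this assay the change to 3-cyanopropyl moves the number the opposite way from the methoxymethyl change (a 2.2-fold higher number from compound 1 to compound 3 (0.34 log units; beyond the scatter)), so carrying an oxygen or nitrogen on the chain does not by itself lower the number at this place. The two chains bearing such atoms also stand well apart (a 4.7-fold higher number from compound 2 to compound 3 (0.68 log units; beyond the scatter)), which shows that this position responds to the identity of the chain, with isopropyl falling in the middle of the three compounds. No available data explain why the nitrile-ended and methoxy-ended chains part ways.

As far as these compounds go, whether the rise follows chain length or the nitrile remains open, and a plain unbranched alkyl chain or a shorter cyanomethyl group would separate the two. From the compounds shown here alone, how an amine or a carboxylic acid at the chain end behaves at this place is also open.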